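This account rests on a few compounds, and the source may have more. Where it says the series, first, only, none or still open, it means among the compounds named here.

Measured so far:
- compound 1 `CC(C)OC(=O)N1CCC(Oc2ncnc3c2CCN3c2ccc(S(C)(=O)=O)cc2)CC1`: 154%
- compound 2 `CC(C)COC(=O)N1CCC(Oc2ncnc3c2CCN3c2ccc(S(C)(=O)=O)cc2F)CC1`: 94%
- compound 3 `Cc1nc(OC2CCN(C(=O)OC(C)C)CC2)c2c(n1)N(c1ccc(S(C)(=O)=O)cc1F)CC2`: 45%

All three were run in a functional assay on CHO-K1 cells with Glucose-dependent insulinotropic receptor (Homo sapiens) as the target, read by a luciferase reporter, with a stated time of 5 h; a higher number here means a larger maximal response, a lower number a smaller maximal response. Compound 1 gives the highest number of the three; compound 2 sits lower and compound 3 lower still, both gaps beyond the scatter. Going by the values given here, no step between two measured compounds that differ in one place is available, so the values of compound 2 and compound 3 show only that other variants of the shared core reach a smaller maximal response than compound 1.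

The unmeasured compound 4 `CC(C)OC(=O)N1CCC(Oc2ncnc3c2CCN3c2ccc(C#N)c(F)c2)CC1` keeps the core of compound 1 and changes one group: 4-cyano-3-fluorophenyl in place of 4-(methylsulfonyl)phenyl on a nitrogen on an aromatic ring in a ring

Nothing measured here isolates this exchange. The only guide is that every departure from compound 1 shown so far, in compound 2 and in compound 3, lands well below it in this assay. Among the compounds with values here, on that basis a downward step of moderate size is expected, with wide uncertainty because the group entering has no measured precedent. The step from compound 1 to compound 4 is estimated at a number 64 percentage points lower from compound 1 to compound 4 (beyond the scatter). Compound 4 is therefore expected to give about 90% in this assay, within a range from 40% to 150%.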

Compound 4, largest response reached (reported as percent of maximum), in percent of the reference or control that the assay uses: 121%
The estimate for compound 4 lay 31 percentage points below the measured number; the range from low to high includes it.
By their numbers in this assay, from the lowest: compound 3; then compound 2; then compound 4; then compound 1.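

In this assay, going by these compounds alone, the exchange of 4-(methylsulfonyl)phenyl for 4-cyano-3-fluorophenyl on a nitrogen on an aromatic ring in a ring gives the first readable step at this position: a number 33 percentage points lower from compound 1 to compound 4 (beyond the scatter). The methylsulfonyl group is therefore not required for a substantial maximal response, since compound 4, which lacks it, still gives 121%, although the exchange costs part of the response seen with compound 1 at 154%. No measurement shown here accounts for the size of this step.

The exchange removes the methylsulfonyl group and introduces the nitrile and the fluorine together, so their separate contributions remain unresolved, and steps involving compound 2 or compound 3 cannot be read because each differs from the other compounds in more than one place. Going by these compounds, it also remains open how 4-cyanophenyl without the fluorine, or a phenyl ring carrying a carboxylic acid or an amine in place of the nitrile, would behave at this position on the core of compound 1.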